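From a dichlorophenyl amide to a chloropyridinyl amide

The source may report more compounds than this note shows. Statements on the series, on what has been measured and on what is new or still open speak of the compounds shown alone.

Measured in a functional assay on MDA-MB-468 cells (Homo sapiens) for antiproliferative activity, read by MTT assay, with a stated time of 72 h; on this read-out lower numbers stand for stronger inhibition and higher numbers for weaker inhibition:
- Compound 1 `Cc1nc(C(=O)Nc2ccc(Cl)c(-c3nnc4c(Cl)cccn34)c2)cs1`: > 100000 nM (a limit of the assay)
- Compound 2 `Cc1cc(Cl)ccc1C(=O)Nc1ccc(Cl)c(-c2nnc3c(Cl)cccn23)c1`: 34300 nM
- Compound 3 `O=C(Nc1ccc(Cl)c(-c2nnc3c(Cl)cccn23)c1)c1ccc(Cl)cc1Cl`: 21600 nM

Compound 3 and compound 2 lie within the scatter of each other, with a 1.6-fold lower number from compound 2 to compound 3 (0.20 log units; within the scatter). Compound 1 is known only through its limit, so the numbers place compound 3 level with compound 2 and clear of that limit.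

The next compound is compound 4 `O=C(Nc1ccc(Cl)c(-c2nnc3c(Cl)cccn23)c1)c1cccnc1Cl`, not yet measured in this assay. It carries 2-chloropyridin-3-yl in place of 2,4-dichlorophenyl on a carbonyl carbon.

Two measured steps changed the same place. Exchanging the 2-methyl-1,3-thiazol-4-yl of compound 1 for a carbon-only aromatic ring gave an at least 4.6-fold lower number from compound 1 to compound 3 (0.66 log units; beyond the scatter) and an at least 2.9-fold lower number from compound 1 to compound 2 (0.46 log units; beyond the scatter). This is a single comparison, and the ring entering in compound 4 is a different one. Still, compound 4 moves back from a carbon-only ring to a ring with a hetero atom, so a modest rise in the number is expected, resting on an at least 4.6-fold lower number from compound 1 to compound 3 (0.66 log units; beyond the scatter).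

The expected change is a 2.3-fold higher number from compound 3 to compound 4 (0.36 log units; beyond the scatter). For compound 4 the estimated value is 50000 nM, with an expected range of 20000 nM to 100000 nM.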

Compound 4, half-maximal inhibitory concentration: > 100000 nM
Compound 4: only a limit was reported (the forecaster's own chance of this, stated with the estimate: 30%); middle value at least 2.0-fold (0.30 log units) away from the limit.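

In this assay compound 4 is reported only as the limit > 100000 nM and not as a number. For the compounds shown here, on the carbonyl carbon, 2-chloropyridin-3-yl in place of 2,4-dichlorophenyl gives an at least 4.6-fold higher number from compound 3 to compound 4 (0.66 log units; beyond the scatter) and in place of 4-chloro-2-methylphenyl gives an at least 2.9-fold higher number from compound 2 to compound 4 (0.46 log units; beyond the scatter) in the same position, so a six-membered ring with a hetero atom now stands against the carbon-only rings, where the earlier compounds offered only the five-membered 2-methyl-1,3-thiazol-4-yl for that comparison. Across these compounds, with no exception among them, the two carbon-only rings give numbers while both rings with a hetero atom end at the same limit: the limit of > 100000 nM in this assay, at which 2 of the 4 values shown sit.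

Going by these compounds, the step between compound 1 and compound 4 cannot be read, since both are limits, so how far these two rings differ stays unknown. Also open, on these data alone, is whether a ring with a hetero atom can give a readable number at this position when it carries another group, such as a pyridine ring with a methoxy group or an amine in place of the chlorine, and whether a saturated ring such as cyclohexyl would behave like the carbon-only aromatic rings.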